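Swapping the Chain-End Group of Compound 1 for a Thiourea

A few compounds are considered here, and "the series" means these few. Any claim that something is new, unique, unknown or untested is made for them only; others in the source may bear on it.

Compound 1 `CN(C)/C(=N/CCCCn1nc(-c2ccccc2)ccc1=O)NC#N` gives 52.9 mg/kg in a functional assay on the whole organism with Rattus norvegicus as the target (on this read-out lower numbers stand for an effect already at smaller amounts and higher numbers for an effect only at larger amounts of compound), the lowest of the three numbers, though compound 2 `CC/N=C(/NC#N)NCCCCn1nc(-c2ccccc2)ccc1=O` with 60.7 mg/kg and compound 3 `CC/N=C(/NC#N)NCCCn1nc(-c2ccccc2)ccc1=O` with 88.5 mg/kg both stand within the scatter of it. Compound 4 `C/N=C(\S)NCCCCn1nc(-c2ccccc2)ccc1=O` differs from compound 1 by a group of 5 heavy atoms (2 carbon, 2 nitrogen, 1 sulfur; no ring) in place of a group of 8 heavy atoms (4 carbon, 4 nitrogen; no ring), on a saturated chain carbon, four bonds along the chain from an aromatic nitrogen. For the measured compounds named here, the one measured step at that position, a 1.1-fold higher number from compound 1 to compound 2 (0.06 log units; within the scatter), exchanged a group for one of the same size and stayed within the scatter; no measured step replaces the departing group with one holding sulfur, so the data give no direction for such a change. For compound 4 the step of a 1.0-fold higher number from compound 1 to compound 4 (0.02 log units; within the scatter) is therefore expected to stay within the scatter. Compound 4 is estimated at 55 mg/kg, between 25 mg/kg and 120 mg/kg.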

Compound 4, dose for half-maximal effect: 17.3 mg/kg
Compound 4: the middle estimate sits 3.2-fold (0.50 log units) above what was measured; the whole stated range lies above it.
By their numbers in this assay, from the lowest: compound 4; then compounds 1, 2 and 3 (each within the scatter of the next).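

Unlike the earlier exchange at this place, which stayed within the scatter, the group holding sulfur on the saturated chain carbon gives a shift beyond the scatter in this assay: a 3.1-fold lower number from compound 1 to compound 4 (0.49 log units; beyond the scatter). The other two steps run the same way, a 3.5-fold lower number from compound 2 to compound 4 (0.55 log units; beyond the scatter) and a 5.1-fold lower number from compound 3 to compound 4 (0.71 log units; beyond the scatter), which sets compound 4 lowest of the four. Nothing shown bears on the reason for this shift. As far as these compounds go, what a urea, with oxygen in place of sulfur, would give at this place stays open, as does how a longer chain would act with the group holding sulfur.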